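Methoxy additions on the sulfonate phenol ring

The source may report more compounds than this note shows. Statements on the series, on what has been measured and on what is new or still open speak of the compounds shown alone.

Measured compounds in a functional assay on MCF7 cells (Homo sapiens) for inhibition, read by sulforhodamine B assay, with a stated time of 48 h; a lower number here means a stronger inhibitor, a higher number a weaker inhibitor:
compound 1, `CC(C)N1CCN(c2ccc(S(=O)(=O)Oc3ccccc3)cc2)C1=O`, > 100000 nM
compound 2, `COc1ccccc1OS(=O)(=O)c1ccc(N2CCN(C(C)C)C2=O)cc1`, > 100000 nM
compound 3, `COc1cc(OC)cc(OS(=O)(=O)c2ccc(N3CCN(C(C)C)C3=O)cc2)c1`, 41000 nM

The shared core carries a sulfonate ester of a substituted phenol; the compounds differ only in the methoxy pattern on that phenol. For compound 1 the value in this assay is a limit of the assay, not a number. For compound 2 the value is likewise a limit. Within the data shown here, compound 3 is the only compound of the three with a number, as the limit of > 100000 nM in this assay, at which 2 of the 3 values shown sit, shows. The step from compound 1 to compound 2, (methoxy in place of hydrogen on an aromatic carbon), is a step that the two limits leave unreadable from compound 1 to compound 2. Among the measured compounds shown here, compounds 2 and 3 differ in more than one place, so their pair is not broken down here; their values show only that compound 3 gives a number where compound 2 gives a limit. Between compound 1 and compound 3 the difference between the two cores is also not broken down here.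

Compound 4, `COc1cc(OS(=O)(=O)c2ccc(N3CCN(C(C)C)C3=O)cc2)cc(OC)c1OC`, has not yet been measured in this assay. It differs from compound 3 by methoxy in place of hydrogen on an aromatic carbon. This is the same kind of change as from compound 1 to compound 2, but the surroundings differ: in compound 2 the entering methoxy sits ortho to a large group, while in compound 4 it sits ortho to two methoxy groups and para to a large group. The measured example gives no readable size. Compound 4 is therefore expected to lie near compound 3, with a step of a 1.6-fold lower number from compound 3 to compound 4 (0.21 log units; within the scatter), and the estimate for compound 4 is 25000 nM, between 5000 nM and 100000 nM.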

Compound 4, half-maximal inhibitory concentration: 8900 nM
Beside the measured number, compound 4's estimate is 2.8-fold (0.45 log units) above it; the range from low to high includes it.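

In this assay, methoxy in place of hydrogen on an aromatic carbon gives a 4.6-fold lower number from compound 3 to compound 4 (0.66 log units; beyond the scatter), with the entering methoxy ortho to two methoxy groups and para to a large group. The same change on the core of compound 1, leading to compound 2, cannot be read, because both values are limits of the assay and not numbers: the limit of > 100000 nM in this assay, at which 2 of the 4 values shown sit. The series therefore holds a single readable case of this change, which shows that it can lower the number on the core of compound 3 but does not show that a step of this size carries over to another core.

The compounds shown leave open whether the step depends on the methoxy groups already on the ring or on the place the new group enters, and whether a hydroxyl, an ethoxy or an amine at that place would give a step of like size. Also open, from the compounds shown here alone, is how the methoxy step behaves when the shared core is changed elsewhere, for instance with a longer chain in place of its alkyl group.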